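The compounds below may be only part of what the source reports. "The series", "measured", "known", "first", "only" and "open" are said of these compounds alone.

Measured compounds in a functional assay on L1210 cells (Mus musculus), with a stated time of 1 days; a higher number here means a more potent compound, by a factor of ten per unit of this negative logarithm, a lower number a less potent compound:
- compound 1 `CC1=C(N2CC2)C(=O)C(CCCOC(N)=O)=C(N2CC2)C1=O`: 5.48
- compound 2 `CC1=C(N2CC2)C(=O)C(C(C)COC(N)=O)=C(N2CC2)C1=O`: 5.31
- compound 3 `CCC(OC)C1=C(N2CC2)C(=O)C(C)=C(N2CC2)C1=O`: 4.84

Compound 1 gives the highest of the three numbers. Its nearest neighbour is compound 2, a number 0.17 log units lower from compound 1 to compound 2 (within the scatter), so the two are not separated. Compound 3 lies furthest away, a number 0.64 log units lower from compound 1 to compound 3 (beyond the scatter), and the step from compound 2 also reaches beyond the scatter, a number 0.47 log units lower from compound 2 to compound 3 (beyond the scatter).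

Compound 4 `CC1=C(N2CC2)C(=O)C(COc2ccccc2)=C(N2CC2)C1=O` is not yet measured. Against compound 1 the change is phenoxy in place of 2-(carbamoyloxy)ethyl on a saturated chain carbon bound to a double-bonded ring carbon. Of the measured steps, those ending at compound 3 bear most directly on this: in both, the side chain on the double-bonded ring carbon gives up its nitrogen-bearing group in favour of one built only from carbon and oxygen, and in both the number in this assay fell by a modest amount, a number 0.64 log units lower from compound 1 to compound 3 (beyond the scatter) and a number 0.47 log units lower from compound 2 to compound 3 (beyond the scatter). The step from compound 1 to compound 2, a like-for-like exchange, stayed within the scatter. A modest downward step is therefore expected for compound 4, a number 0.58 log units lower from compound 1 to compound 4 (beyond the scatter), since compound 3 gave 4.84 after a comparable change. The estimate for compound 4 in this assay is 4.9, with a range from 4.3 to 5.5.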

Compound 4, logarithm of the reciprocal of the active concentration, log(1/C): 3.89
Compound 4: middle estimate off by 1.01 log units, on the high side; the whole stated range lies above it.
By their numbers in this assay, from the lowest: compound 4; then compound 3; then compounds 2 and 1 (each within the scatter of the next).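

In this assay, phenoxy in place of 2-(carbamoyloxy)ethyl on a saturated chain carbon bound to a double-bonded ring carbon gives a large fall, a number 1.59 log units lower from compound 1 to compound 4 (beyond the scatter). The earlier change at this place that also gave up the nitrogen-bearing group was only modest, a number 0.64 log units lower from compound 1 to compound 3 (beyond the scatter), so the first three compounds understated how far the number can move with this side chain alone; compound 3 stands at 4.84 and compound 4 lies lower at 3.89, although both side chains are built only from carbon and oxygen. Nothing available on these compounds accounts for the size of the fall.

The exchange removes the carbamoyloxy group's hydrogen-bond donor and introduces a six-membered aromatic ring in one step, so the compounds shown do not separate the contribution of either change. A cyclohexyloxy group in place of phenoxy would address the aromatic ring, while a hydroxyl or primary amine at the end of the chain of compound 1 would show how much of the number depends on the carbamate itself.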